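Formyl to hydroxymethyl on the chain of compound 3

This account rests on a few compounds, and the source may have more. Where it says the series, first, only, none or still open, it means among the compounds named here.

Of the compounds shown here, three have been read so far in a functional assay on HepG2 cells (Homo sapiens) for cytotoxicity, with a stated time of 72 h (on this read-out lower numbers stand for an effect already at smaller amounts and higher numbers for an effect only at larger amounts of compound), and none has yet given a number. Compound 1 (`C=C[C@@](C)(/C=C/c1ccc(OCc2ccccc2)cc1)CCC=C(C)C`) gives > 52000 nM as a limit. Compound 2 (`C=C[C@@](C)(/C=C/c1ccc(OS(=O)(=O)c2ccc(C)cc2)cc1)CCC=C(C)C`) gives > 52000 nM as a limit. Compound 3 (`C=C[C@@](C)(/C=C/c1ccc(O)cc1)CCC=O`) gives > 52000 nM as a limit. The series therefore stands at one shared ceiling (the limit of > 52000 nM in this assay, at which 3 of the 3 values shown sit) and offers no ranking among these compounds.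

Compound 4 (`C=C[C@@](C)(/C=C/c1ccc(O)cc1)CCCO`) comes from compound 3 by the change hydroxymethyl in place of formyl on a saturated chain carbon, three bonds along the chain from two double-bonded chain carbons and carries hydroxymethyl in place of formyl on a saturated chain carbon, three bonds along the chain from two double-bonded chain carbons. For the measured compounds named here, no step between two measured compounds is available, so nothing measured gives the size of this change. In this assay no shift beyond the usual scatter is expected, in either direction. The expectation rests on compound 3 with > 52000 nM as its limit. The estimated a number no higher from compound 3 to compound 4 (the limit leaves the size open) is accordingly small. For compound 4 the expected value is 52000 nM with an estimated range from 30000 nM to 60000 nM and a report as a limit is the likeliest outcome.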

Compound 4, half-maximal effective concentration: > 52000 nM
Compound 4: no number, only a limit (the forecaster's own chance of this, stated with the estimate: 80%); the middle value lies on the limit itself.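

In this assay compound 3 and compound 4 both stand only as limits, and the step between them cannot be read. Still open is how far any of the compounds shown lies from the ceiling, and whether any change on the shared core yields a number at all, with the series resting at a single value: the limit of > 52000 nM in this assay, at which 4 of the 4 values shown sit.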